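Adding a second hydroxy to the shared core

This account rests on a few compounds, and the source may have more. Where it says the series, first, only, none or still open, it means among the compounds named here.

Within the data shown here, compound 2 `Oc1ccc(-c2nc3cc(O)ccc3s2)cc1` is one of two compounds measured in a functional assay on WiDr cells (Homo sapiens) for cytotoxicity (a higher number here means a weaker inhibitor, a lower number a stronger inhibitor), where compound 2 gives 62200 nM. Compound 1 `Oc1cc(O)c2nc(-c3ccc(O)c(O)c3)sc2c1` gives 47700 nM in this assay, and the two numbers lie within the usual scatter of each other, so neither can be called the stronger. Compound 3 `Oc1ccc(-c2nc3cc(O)c(O)cc3s2)cc1` carries hydroxy in place of hydrogen on an aromatic carbon, placed ortho to a hydroxy group on the fused ring. Among the measured compounds shown here, no measured pair shows what such a change does here, so the step from compound 2 to compound 3 is expected to stay within the scatter, at most a slight lowering of the number: a 1.4-fold lower number from compound 2 to compound 3 (0.14 log units; within the scatter). For compound 3 the estimated value in this assay is 45000 nM, with a likely range from 15000 nM to 130000 nM.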

Compound 3, half-maximal inhibitory concentration: 24700 nM
Estimate against measurement, compound 3: 1.8-fold (0.26 log units) above; measured number inside the range.
By their numbers in this assay, from the lowest: compounds 3, 1 and 2 (each within the scatter of the next, the first and the last beyond it).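

In this assay, among these compounds, the change from hydrogen to hydroxy, ortho to a hydroxy group on the fused ring, gives a 2.5-fold lower number from compound 2 to compound 3 (0.40 log units; beyond the scatter) and is the first single change here that can be read. It shows that this position accepts a second hydroxy with a modest gain rather than a loss. Nothing at hand explains this gain.

Going by these compounds, whether the gain needs a hydroxy specifically stays open, since a methoxy or an amine at this position could behave differently. One step on one cell line also cannot show whether the same change would help on other cores.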